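A few compounds are considered here, and "the series" means these few. Any claim that something is new, unique, unknown or untested is made for them only; others in the source may bear on it.

Compound 1, `C[C@H](c1ccc(-c2ccccc2-c2nc(=O)o[nH]2)cc1)N(CC1CC1)c1nc2c(C(=O)O)cccc2o1`, and compound 2, `CCCCN(c1nc2c(NS(C)(=O)=O)cccc2o1)[C@H](C)c1ccc(-c2ccccc2-c2nnn[nH]2)cc1`, were both examined in an ADME assay on the whole organism (Macaca fascicularis) for pharmacokinetics, read by LC-MS, using cassette dosing, at a dose of 1 mg/kg by the oral route; on this read-out lower numbers stand for lower exposure and higher numbers for higher exposure at the dose given. Compound 1 gives 11600 ng.h/mL in this assay, while compound 2 gives 73.8 ng.h/mL. Of the two numbers in hand, compound 2 stands at the lower one; the number for compound 1 lies far above it, well beyond the scatter of repeated measurements, so the two compounds clearly differ on this read-out. Since compound 1 and compound 2 differ from each other in several places at once, nothing more can be drawn from that pair than what the two values themselves show.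

Compound 3, `CCCCN(c1nc2c(CO)cccc2o1)[C@H](C)c1ccc(-c2ccccc2-c2nnn[nH]2)cc1`, has not yet been measured. It differs from compound 2 in a single place: hydroxymethyl in place of methanesulfonamido on an aromatic carbon. Among the compounds with values here, no measured pair covers this exact change, so no step size is available from the data; the expectation for compound 3 rests only on the number for compound 2 and on the change itself. The step from compound 2 to compound 3 is expected to be a 2.0-fold higher number from compound 2 to compound 3 (0.31 log units; beyond the scatter), a modest rise that may not clear the scatter. Compound 3 is therefore estimated to give 150 ng.h/mL in this assay, within a range from 30 ng.h/mL to 700 ng.h/mL.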

Compound 3, area under the concentration-time curve: 20 ng.h/mL
Compound 3: the middle estimate sits 7.5-fold (0.88 log units) above what was measured, outside the stated range (below it).
By their numbers in this assay, from the lowest: compound 3; then compound 2; then compound 1.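

In this assay, within the data shown here, the change on this aromatic carbon, ortho to a fused ring and meta to a fused ring, gives a 3.7-fold lower number from compound 2 to compound 3 (0.57 log units; beyond the scatter), the first single-place step that can be read. It shows that the group at this position affects oral exposure at the dose given: hydroxymethyl, with 2 heavy atoms, does not match methanesulfonamido, with 5 heavy atoms, and the loss is modest but beyond the scatter, so the two groups are not interchangeable here. No measurement accompanies these numbers that would tell what lies behind the step.

The compounds shown leave open how other groups on this same carbon would read, for example an amine, a methoxy group or a primary amide, and so whether exposure follows the size of the group or something else about it. From the compounds shown here alone, it also remains open whether the same exchange would give a step of similar size on a different background, such as a longer chain in place of the butyl chain or the core of compound 1.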